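Halogen swap on the benzylamine core: chloro to fluoro

The source may report more compounds than this note shows. Statements on the series, on what has been measured and on what is new or still open speak of the compounds shown alone.

Measured so far in an assay on Sf9 cells for inhibition of Amine oxidase [flavin-containing] A (Homo sapiens), with stated times of 15 min and 60 min; a higher number here means a weaker inhibitor, a lower number a stronger inhibitor:
compound 1 `Cc1cc(OCc2cccc(F)c2)ccc1CN[C@@H](C)C(N)=O` gives > 10000 nM, a limit of the assay and not a number.
compound 2 `NC(=O)[C@@H]1CCN1Cc1ccc(OCc2cccc(F)c2)cc1Cl` gives 2130 nM.
compound 3 `C[C@H](NCc1ccc(OCc2cccc(F)c2)cc1Cl)C(N)=O` gives 12000 nM.

Compound 3 stands highest of the two numbers in this assay; the nearest number belongs to compound 2, with the step of a 5.6-fold higher number from compound 2 to compound 3 (0.75 log units; beyond the scatter). Compound 4 `C[C@H](NCc1ccc(OCc2cccc(F)c2)cc1F)C(N)=O` differs from compound 3 in one place: fluoro in place of chloro on an aromatic carbon. For the measured compounds named here, the only measured step at that position, a step that the limit leaves unreadable from compound 1 to compound 3, is unreadable, hidden by the limit of > 10000 nM in this assay, at which 1 of the 3 values shown sits. Going by the values given here, no measured step therefore bears a readable size on this change, and no direction beyond the scatter is expected. Compound 4 is estimated at 13000 nM, between 4000 nM and 40000 nM. The expected step of a 1.1-fold higher number from compound 3 to compound 4 (0.03 log units; within the scatter) is accordingly small.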

Compound 4, half-maximal inhibitory concentration: > 10000 nM
Compound 4: no number, only a limit (the forecaster's own chance of this, stated with the estimate: 35%); the middle value does not contradict the limit.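

No step from compound 1 or compound 3 to compound 4 can be read, as compound 4 gives a limit of the assay and not a number: the limit of > 10000 nM in this assay, at which 2 of the 4 values shown sit.

The compounds shown leave open how fluoro in place of chloro on an aromatic carbon shifts the number, in size or direction.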